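This account rests on a few compounds, and the source may have more. Where it says the series, first, only, none or still open, it means among the compounds named here.

Compound 3 `Nc1n[nH]c2cc(-c3ccc(=O)n(Cc4cccc(Cl)c4)c3)ccc12` stands second highest of the three numbers in an assay for inhibition of MAP kinase-interacting serine/threonine-protein kinase 2 (Homo sapiens), read by luminescence and ADP-Glo, with a stated time of 2 h (on this read-out lower numbers stand for stronger inhibition and higher numbers for weaker inhibition), where compound 3 gives 6 nM. Within the data shown here, compound 1 `Nc1n[nH]c2cc(-c3ccc(=O)n(Cc4ccccc4F)c3)ccc12` gives 4 nM, and the only single-point step on this ring, a 1.5-fold higher number from compound 1 to compound 3 (0.18 log units; within the scatter), changes little. Among the measured compounds shown here, compound 2 `CC(=O)Nc1cccc(Cn2cc(-c3ccc4cn[nH]c4c3)ccc2=O)c1` gives 43 nM; it already carries the acetamido group on the side-chain ring but lacks the amino group on the shared core, so no single-point step connects it to compound 3. Compound 4 `CC(=O)Nc1cccc(Cn2cc(-c3ccc4c(N)n[nH]c4c3)ccc2=O)c1` differs from compound 3 by acetamido in place of chloro on an aromatic carbon. For the measured compounds named here, no measured step covers this swap directly; the one step on this ring stayed within the scatter, while compound 2 shows a clearly higher number. For compound 4 the estimate is 10 nM (range 3 nM to 35 nM), an expected step of a 1.7-fold higher number from compound 3 to compound 4 (0.22 log units; within the scatter).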

Compound 4, half-maximal inhibitory concentration: 8 nM
For compound 4 the middle estimate is 1.3-fold (0.10 log units) above the measured one, within the range that was stated.
By their numbers in this assay, from the lowest: compounds 1, 3 and 4 (each within the scatter of the next); then compound 2.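

Acetamido in place of chloro on this aromatic carbon adds heavy atoms, a hydrogen-bond donor and a hydrogen-bond acceptor, yet the number holds (a 1.3-fold higher number from compound 3 to compound 4 (0.12 log units; within the scatter)). Among these compounds, with acetamido fixed, amino in place of hydrogen on an aromatic carbon of the shared core gives the only step so far beyond the scatter (a 5.4-fold lower number from compound 2 to compound 4 (0.73 log units; beyond the scatter)). No measured evidence bears on the size of either step.

Still open, going by these compounds, is how a carboxylic acid, an amine or a longer chain would read on this aromatic carbon. Also open, on these data alone, is whether the amino step keeps its size with chloro on the side-chain ring.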